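The source may hold more compounds than are shown below. What is called first, only, known or untested is meant among the compounds shown, and "the series" means these compounds.

Working notes on the series. Compound 1 `COc1ccc(-c2[nH]c3ccccc3c2/C=C(\C#N)S(=O)(=O)c2ccccc2)cc1` is one of two compounds with a number in a functional assay on SNB-75 cells (Homo sapiens) for inhibition, read by sulforhodamine B assay, with a stated time of 48 h; a lower number here means a stronger inhibitor of growth, a higher number a weaker inhibitor of growth: compound 1 gives 379 nM. Compound 2 `COc1ccc(-c2[nH]c3ccc(OC)cc3c2C=C(C#N)C#N)cc1` differs in more than one place from compound 1; in this assay compound 2 gives 593 nM; the two numbers lie within the scatter of each other, so no order between compound 1 and compound 2 can be read from them.

Compound 3 `N#C/C(=C\c1c(-c2ccccc2)[nH]c2ccccc12)S(=O)(=O)c1ccccc1` is not yet measured. From compound 1 it differs in one place: hydrogen in place of methoxy on an aromatic carbon. Going by the values given here, no measured pair shows this change, so its size has to be guessed. The expected step of a 1.6-fold higher number from compound 1 to compound 3 (0.20 log units; within the scatter) is small, toward a higher number, and may not exceed the scatter. The estimate for compound 3 in this assay is 600 nM, with a range from 250 nM to 1500 nM.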

Compound 3, concentration for 50% growth inhibition: 1700 nM
Compound 3: the middle estimate sits 2.8-fold (0.45 log units) below what was measured, outside the stated range (above it).
By their numbers in this assay, from the lowest: compounds 1 and 2 (each within the scatter of the next); then compound 3.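

Removing the methoxy from the 4-methoxyphenyl group, at the place para to a large group, gives the series its first readable single change. In this assay this change raises the number (a 4.5-fold higher number from compound 1 to compound 3 (0.65 log units; beyond the scatter)), beyond the scatter, so this place on the ring is not indifferent to what it carries, at least in this pair. Nothing available bears on why the number rises with this change.

Open, on these data alone, is whether a hydroxyl, a fluorine or a dimethylamino group at this place would read closer to methoxy or to hydrogen, and whether an ethoxy group would hold the number of compound 1. Also open, as far as these compounds go, is whether the same change would give a step of similar size on the core of compound 2.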